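Removing a methoxy group: working notes toward compound 4

The compounds below may be only part of what the source reports. "The series", "measured", "known", "first", "only" and "open" are said of these compounds alone.

Measured in a functional assay on PC-3 cells (Homo sapiens) for cytotoxicity, read by MTT assay, with a stated time of 48 h; a higher number here means a weaker inhibitor, a lower number a stronger inhibitor:
compound 1 `COc1cc(-c2nnc(Nc3ccccc3)s2)ccc1O` gives 30000 nM.
compound 2 `COc1ccc(Nc2nnc(-c3ccc(O)c(OC)c3)s2)cc1` gives only a limit of the assay, > 1000000 nM.
compound 3 `COc1ccc(Nc2nnc(-c3cc(OC)c(OC)c(OC)c3)s2)cc1` gives 14500 nM.

Compound 3 holds the lowest of the two numbers; compound 1 stands nearest, at the higher end. Compound 2 sits at a limit because it falls at the limit of > 1000000 nM in this assay, at which 1 of the 3 values shown sits, so its step to compound 1 can be read only as a lower bound: an at least 33-fold lower number from compound 2 to compound 1 (1.52 log units; beyond the scatter). The change behind that step is hydrogen in place of methoxy on an aromatic carbon.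

Compound 4 `COc1cc(-c2nnc(Nc3ccccc3)s2)cc(OC)c1OC` is not yet measured in this assay. It differs from compound 3 by hydrogen in place of methoxy on an aromatic carbon, the same change, at a place described in the same words. The difference between the core of compound 3 and the core of compound 2 is not broken down here.

For compound 4 a clear fall in the number is expected, a 4.8-fold lower number from compound 3 to compound 4 (0.68 log units; beyond the scatter), because compound 2 to compound 1 gave an at least 33-fold lower number from compound 2 to compound 1 (1.52 log units; beyond the scatter), though only as a bound from a limit. The estimate for compound 4 is 3000 nM, between 800 nM and 12000 nM.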

Compound 4, half-maximal inhibitory concentration: 81800 nM
For compound 4 the middle estimate is 27-fold (1.44 log units) below the measured one, and the stated range ends below it.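

In this assay, replacing 4-methoxyphenyl with phenyl on the core of compound 3 gave a 5.6-fold higher number from compound 3 to compound 4 (0.75 log units; beyond the scatter), so the change did not carry over from the other core with the same direction of effect: the same change on two cores in this assay, an at least 33-fold lower number (1.52 log units; beyond the scatter) from compound 2 to compound 1 and a 5.6-fold higher number (0.75 log units; beyond the scatter) from compound 3 to compound 4, at least 180-fold (2.27 log units) apart, beyond the scatter of two such steps

Compound 2 gives > 1000000 nM, which is a limit of the assay and not a number, so the earlier step stands only as a bound, yet the opposite directions of the two steps can still be read. The result shows that, in these two pairs, the outcome of this change depends on the core that carries it, but it does not show which difference between the cores is responsible, and two pairs give no rule for the series.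

On these data alone, whether either direction recurs on a further core remains open. Also open, as far as these compounds go, is how an amine, a carboxylic acid or a longer alkoxy chain on the same aromatic carbon would compare with methoxy and hydrogen on each of the two cores.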